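A few compounds are considered here, and "the series" means these few. Any claim that something is new, unique, unknown or untested is made for them only; others in the source may bear on it.

Compound 1, `COc1cccc(Nc2nc(Oc3cccc(NC(=O)C=C(C)C)c3)c3sccc3n2)c1`, in a functional assay on A549 cells (Homo sapiens) for inhibition, read by MTT assay, with a stated time of 72 h; on this read-out lower numbers stand for stronger inhibition and higher numbers for weaker inhibition: 27700 nM
Compound 2, `COc1ccc(Nc2nc(Oc3cccc(NC(=O)C=C(C)C)c3)c3sccc3n2)cn1`, in this assay: 40100 nM
Compound 3, `CC(C)=CC(=O)Nc1cccc(Oc2nc(Nc3cccc(C#N)c3)nc3ccsc23)c1`, in this assay: 16900 nM

Compound 3 gives the lowest of the three numbers in this assay, though its gap to compound 1 is within the scatter, a 1.6-fold lower number from compound 1 to compound 3 (0.21 log units; within the scatter), and only its gap to compound 2 goes beyond it, a 2.4-fold lower number from compound 2 to compound 3 (0.38 log units; beyond the scatter). The remaining measured step, a 1.4-fold higher number from compound 1 to compound 2 (0.16 log units; within the scatter), also lies within the scatter. All three steps concern the group on the nitrogen attached to the shared core, not the amide side.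

Compound 4, `CCC/C=C/C(=O)Nc1cccc(Oc2nc(Nc3cccc(C#N)c3)nc3ccsc23)c1`, differs from compound 3 only at the amide: pent-1-en-1-yl in place of 2-methylprop-1-en-1-yl on a carbonyl carbon. Within the data shown here, no measured step touches this part of the molecule, so nothing in the data points to a change in either direction. On that basis compound 4 is expected to sit close to compound 3 in this assay, with a step of a 1.0-fold higher number from compound 3 to compound 4 (0.00 log units; within the scatter) that is not expected to exceed the scatter. The estimate for compound 4 is 17000 nM, in the range from 7000 nM to 45000 nM.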

Compound 4, half-maximal inhibitory concentration: 16700 nM
Beside the measured number, compound 4's estimate is 1.0-fold (0.01 log units) above it; measured number inside the range.
By their numbers in this assay, from the lowest: compounds 4, 3, 1 and 2 (each within the scatter of the next, the first and the last beyond it).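

Among these compounds, at the amide side, which no earlier step had touched, the change from 2-methylprop-1-en-1-yl to pent-1-en-1-yl on the carbonyl carbon gives a 1.0-fold lower number from compound 3 to compound 4 (0.01 log units; within the scatter) in this assay and so stays within the scatter. Among the compounds shown here, this is the first sign that the number in this assay can hold when this chain is altered, at least for these two chains, which both keep one double bond outside aromatic rings and carry no ring, hydrogen-bond donors, hydrogen-bond acceptors or net charge. No supporting data bear on why the two chains read alike. Going by these compounds, whether this holds for other kinds of group on the carbonyl carbon, such as a saturated pentyl chain, a chain ending in a dimethylamino group or one ending in a carboxylic acid, stays open. So does whether a phenyl ring at this place would leave the number within the scatter.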